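This account rests on a few compounds, and the source may have more. Where it says the series, first, only, none or still open, it means among the compounds named here.

Measured compounds:

Compound 1 `CCOC(=O)Nc1cc(NCCN(CC)CC)c2nc(-c3cccs3)c(-c3cccs3)nc2n1` gives 6300 nM in an ADME assay on Vero cells (Chlorocebus sabaeus) for cytotoxicity, read by CellTiter-Glo, with a stated time of 72 h; a higher number here means that more compound is tolerated, a lower number that less compound is tolerated.
Compound 2 `CCOC(=O)Nc1cc(NCCN(CC)CC)c2nc(-c3ccco3)c(-c3ccco3)nc2n1` gives 5500 nM in this assay.
Compound 3 `CCOC(=O)Nc1cc(NCCN(C)C)c2nc(-c3cccs3)c(-c3cccs3)nc2n1` gives 1600 nM in this assay.

Compound 2 and compound 1 sit within the scatter of each other in this assay; the difference between their two cores is not broken down here. Compound 3 differs from compound 1 by dimethylamino in place of diethylamino on a saturated chain carbon, two bonds along the chain from a nitrogen on an aromatic ring, and this brought a 3.9-fold lower number from compound 1 to compound 3 (0.60 log units; beyond the scatter), a modest drop that still lies beyond the scatter.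

Compound 4 `CCOC(=O)Nc1cc(NCCN(C)C)c2nc(-c3ccco3)c(-c3ccco3)nc2n1` has not yet been measured. It differs from compound 2 by dimethylamino in place of diethylamino on a saturated chain carbon, two bonds along the chain from a nitrogen on an aromatic ring, the same change, at the same place, as that from compound 1 to compound 3. Since that earlier step gave a 3.9-fold lower number from compound 1 to compound 3 (0.60 log units; beyond the scatter), a step of about the same size is expected here, namely a 3.7-fold lower number from compound 2 to compound 4 (0.56 log units; beyond the scatter). Compound 4 is therefore estimated at 1500 nM, with a plausible range from 600 nM to 4000 nM.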

Compound 4, half-maximal cytotoxic concentration: 37000 nM
Compound 4: the middle estimate sits 25-fold (1.39 log units) below what was measured, and the stated range ends below it.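

On the core of compound 2, dimethylamino in place of diethylamino brought a 6.7-fold higher number from compound 2 to compound 4 (0.83 log units; beyond the scatter), so the change did not carry over from the core of compound 1 in either direction or size. The two steps in this assay run opposite ways, and the gap between them is larger than repeat measurements would explain: the same change on two cores in this assay, a 3.9-fold lower number (0.60 log units; beyond the scatter) from compound 1 to compound 3 and a 6.7-fold higher number (0.83 log units; beyond the scatter) from compound 2 to compound 4, 26-fold (1.42 log units) apart, beyond the scatter of two such steps

Within the data shown here, this shows that a step seen on one core was a poor guide to the same change on the other, but with only one pair per core it does not show why the cores differ or how the change would behave on a third core. Other amines at the same place, such as pyrrolidine or morpholine, remain open, as does a longer chain carrying the amine. Whether these would also behave differently on the two cores is equally unknown.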